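Series notes: from compound 1 to compound 3

The source may report more compounds than this note shows. Statements on the series, on what has been measured and on what is new or still open speak of the compounds shown alone.

Measured so far:
compound 1, `CCn1cc(-c2nc3ccccc3s2)c(=O)c2cc(F)c(N3CCNCC3)cc21`: 28700 nM
compound 2, `CCn1cc(-c2nc3ccc(Cl)cc3[nH]2)c(=O)c2cc(F)c(N3CCNCC3)cc21`: 1600 nM

In a functional assay on KB cells (Homo sapiens) for cytotoxicity, read by MTT assay, with a stated time of 48 h (a higher number here means a weaker inhibitor, a lower number a stronger inhibitor), compound 1 gives 28700 nM and stands highest of the two numbers, the nearest being compound 2 with 1600 nM. Among the measured compounds shown here, the only measured step, an 18-fold lower number from compound 1 to compound 2 (1.25 log units; beyond the scatter), concerns 6-chloro-1H-benzimidazol-2-yl in place of 1,3-benzothiazol-2-yl, not a group added onto the retained ring, so no measured step bears directly on compound 3, `CCn1cc(-c2nc3ccc([N+](=O)[O-])cc3s2)c(=O)c2cc(F)c(N3CCNCC3)cc21`. Compound 3 differs from compound 1 by nitro in place of hydrogen on an aromatic carbon. With nothing to anchor a direction, no step beyond the scatter is expected; a 1.4-fold lower number from compound 1 to compound 3 (0.16 log units; within the scatter) is the working estimate. Compound 3 is therefore expected near 20000 nM, within 5000 nM to 80000 nM.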

Compound 3, half-maximal inhibitory concentration: 700 nM
Estimate against measurement, compound 3: 29-fold (1.46 log units) above; measured number below the stated range.
By their numbers in this assay, from the lowest: compound 3; then compound 2; then compound 1.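

In this assay, the carbon-only six-membered aromatic ring of the fused system in compound 1 proves responsive to substitution: nitro in place of hydrogen gives a 41-fold lower number from compound 1 to compound 3 (1.61 log units; beyond the scatter) on that ring. The earlier step exchanged the whole fused group, whereas this one retains it and changes a single hydrogen, so one substituent there is enough for a large step. Nothing available here accounts for the size of this step. As far as these compounds go, whether the step is specific to nitro remains open; an amine, a methoxy group or a carboxylic acid at the same place would test this. From the compounds shown here alone, the other carbons of that ring also remain open.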